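The source may hold more compounds than are shown below. What is called first, only, known or untested is meant among the compounds shown, and "the series" means these compounds.

Compound 1 `O=C(Nc1ccc(F)cc1)c1c(NO)cc(-c2cccs2)oc1=O` and compound 2 `O=C(Nc1ccc(Cl)cc1)c1c(NO)cc(-c2cccs2)oc1=O` differ only by chloro in place of fluoro on an aromatic carbon. In an ADME assay on Huh-7 cells (Homo sapiens) for cytotoxicity, with a stated time of 3 days (on this read-out higher numbers stand for lower toxicity in this test and lower numbers for higher toxicity in this test), compound 1 gives > 20000 nM, which is a limit of the assay rather than a number. Compound 2 likewise gives > 20000 nM in this assay, again a limit. The step that the two limits leave unreadable from compound 1 to compound 2 cannot be sized, since (the limit of > 20000 nM in this assay, at which 3 of the 3 values shown sit). Compound 3 `O=C(Nc1ccc(F)cc1)c1c(NCCO)cc(-c2cccc(Br)c2)oc1=O` rests on a different core, and the difference between the two cores is not broken down here. In this assay compound 3 gives > 20000 nM, also a limit. Compound 4 `O=C(Nc1ccc(Cl)cc1)c1c(NCCO)cc(-c2cccc(Br)c2)oc1=O` is the untested partner of compound 3, made by the same change, (chloro in place of fluoro on an aromatic carbon), at the same place. Because (the limit of > 20000 nM in this assay, at which 3 of the 3 values shown sit), the expected step is a step that the limit leaves unreadable from compound 3 to compound 4. Compound 4 is estimated at 25000 nM in this assay, most likely appearing as a further limit.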

Compound 4, half-maximal cytotoxic concentration: 17000 nM
Beside the measured number, compound 4's estimate is 1.5-fold (0.17 log units) above it; the measured number falls inside the stated range.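

Carried to the core of compound 3, the change from fluoro to chloro in this assay gives an at least 1.1-fold lower number from compound 3 to compound 4 (0.07 log units; that floor lies within the scatter) on this read-out, so no real shift can be claimed for this pair. For the compounds shown here, the same change on the core of compound 1 cannot be sized, so the two cores offer no pair of sizes to set side by side, because its two ends are limits: the limit of > 20000 nM in this assay, at which 3 of the 4 values shown sit. The data therefore neither show that the change carries over from one core to the other nor show that it fails to.

On these data alone, it remains open how this read-out would respond to an amine or a carboxylic acid in place of the halogen on the aromatic ring. As far as these compounds go, whether a further core would give a step that can be read in full also remains open.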